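The source may report more compounds than this note shows. Statements on the series, on what has been measured and on what is new or still open speak of the compounds shown alone.

For the measured compounds named here, compound 1 `CCCCCCCCCCCC[C@@H](O)[C@H]1CC[C@H]([C@H](O)CCCCCCCCCCN(C)C(=O)c2ccnn2C)O1` gives 8910 nM in a functional assay on MDA-MB-231 cells (Homo sapiens) for inhibition, read by sulforhodamine B assay, with a stated time of 48 h (a higher number here means a weaker inhibitor of growth, a lower number a stronger inhibitor of growth), and stands lowest of the two numbers measured so far. Compound 2 `CCCCCCCCCCCC[C@@H](O)[C@H]1CC[C@H]([C@H](O)CCCCCCCCCCC(=O)Nc2ccnn2C)O1` gives 100000 nM in this assay and sits at the far end of the pair. Going by the values given here, the single measured step, an 11-fold higher number from compound 1 to compound 2 (1.05 log units; beyond the scatter), shows that changing the group on the chain end at this place can move the number a long way. Among the compounds with values here, compound 3 `CCCCCCCCCCCC[C@@H](O)[C@H]1CC[C@H]([C@H](O)CCCCCCCCCCOC(=O)c2ccnn2C)O1` is built from compound 1 with ((1-methyl-1H-pyrazol-5-yl)carbonyl)oxy in place of methyl((1-methyl-1H-pyrazol-5-yl)carbonyl)amino on a saturated chain carbon, ten or more bonds along the chain from an oxygen on a saturated carbon and a saturated ring carbon as the only change. Within the data shown here, the step from compound 1 to compound 2 is the one measured step that bears on it. In both cases the methyl((1-methyl-1H-pyrazol-5-yl)carbonyl)amino group leaves the same place, and that step was large. A shift in the same direction is therefore expected for compound 3, though likely smaller. Compound 3 is expected to give 25000 nM with a range from 7000 nM to 90000 nM in this assay. The expected step is a 2.8-fold higher number from compound 1 to compound 3 (0.45 log units; beyond the scatter) toward weaker inhibition of growth.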

Compound 3, concentration for 50% growth inhibition: 100000 nM
Compound 3: the middle estimate sits 4.0-fold (0.60 log units) below what was measured; the measured number lies above the stated range.
By their numbers in this assay, from the lowest: compound 1; then compounds 2 and 3 (each within the scatter of the next).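

Putting ((1-methyl-1H-pyrazol-5-yl)carbonyl)oxy in place of methyl((1-methyl-1H-pyrazol-5-yl)carbonyl)amino gives an 11-fold higher number from compound 1 to compound 3 (1.05 log units; beyond the scatter), so a second replacement at this position also moves the number a long way in this assay. The two replacements do not separate, with no change at the digits printed from compound 2 to compound 3 (within the scatter), and of these three compounds compound 1, carrying the methyl((1-methyl-1H-pyrazol-5-yl)carbonyl)amino group, alone stands apart from the other two. Nothing measured on these compounds accounts for this difference.

Still open, going by these compounds, is whether the methyl on the amide nitrogen matters or only the nitrogen itself, a question that ((1-methyl-1H-pyrazol-5-yl)carbonyl)amino, with the amide hydrogen in place of that methyl, would address. Also open, on these data alone, is how a longer chain or a plain amine at this chain end would read in this assay.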